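Swapping a Fluorophenyl for a Naphthyl Group

This account rests on a few compounds, and the source may have more. Where it says the series, first, only, none or still open, it means among the compounds named here.

Compound 3 `NC(=O)c1cnn2c1N(C(=O)Nc1cccc(F)c1)C(c1ccccc1)C2` gives the lowest number among the compounds measured in a functional assay on cells (Neutrophil, Homo sapiens) for inhibition, with a stated time of 10 min (a lower number here means a stronger inhibitor, a higher number a weaker inhibitor), at 3.9 nM. Going by the values given here, its nearest neighbour, compound 1 `O=C(Nc1cccc(F)c1)N1c2ccnn2CC1c1ccccc1`, gives 12.1 nM; the step of a 3.1-fold lower number from compound 1 to compound 3 (0.49 log units; beyond the scatter) is the only fully measured step. Compound 2 `O=C(Nc1cccc2ccccc12)N1c2ccnn2CC1c1ccccc1` reaches only a limit in this assay, at > 1000 nM. Compound 1 and compound 2 differ in the same way that compound 4 `NC(=O)c1cnn2c1N(C(=O)Nc1cccc3ccccc13)C(c1ccccc1)C2` differs from compound 3: naphthalen-1-yl in place of 3-fluorophenyl on an amide-type nitrogen. On the core of compound 1, that same exchange carried the number out of the measurable range (the limit of > 1000 nM in this assay, at which 1 of the 3 values shown sits), which points to a large loss. The step from compound 3 to compound 4 is therefore expected to be a 380-fold higher number from compound 3 to compound 4 (2.59 log units; beyond the scatter). Compound 4 is estimated at 1500 nM, within a range from 200 nM to 10000 nM.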

Compound 4, half-maximal inhibitory concentration: 110 nM
Compound 4: the middle estimate sits 14-fold (1.13 log units) above what was measured; measured number below the stated range.
By their numbers in this assay, from the lowest: compound 3; then compound 1; then compound 4. At a limit, above all of these: compound 2.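

Naphthalen-1-yl in place of 3-fluorophenyl on the amide-type nitrogen now has a measured cost in this assay, with the carbamoyl group present: a 28-fold higher number from compound 3 to compound 4 (1.45 log units; beyond the scatter). Carbamoyl in place of hydrogen on an aromatic carbon gives an at least 9.0-fold lower number from compound 2 to compound 4 (0.95 log units; beyond the scatter), so with naphthalen-1-yl it brings the number back into the measurable range. The same change differs in size between the two cores: the same change on two cores in this assay, a 3.1-fold lower number (0.49 log units; beyond the scatter) from compound 1 to compound 3 and an at least 9.0-fold lower number (0.95 log units; beyond the scatter) from compound 2 to compound 4, at least 2.9-fold (0.46 log units) apart, beyond the scatter of two such steps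

Open, from the compounds shown here alone, is whether a carboxylic acid or an amine in place of the carbamoyl group would keep the number as low. Also open, going by these compounds, is how a plain phenyl group would fare on this nitrogen.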